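Halogen at the benzoyl ortho position: chloro to bromo

A few compounds are considered here, and "the series" means these few. Any claim that something is new, unique, unknown or untested is made for them only; others in the source may bear on it.

Compound 3 `CC(C)(C)N(NC(=O)c1ccccc1Cl)C(=O)c1ccccc1Cl` gives 331 nM in an assay on cells for agonist activity at ecdysone receptor (Bombyx mori), read by a luciferase reporter, with a stated time of 24 h (on this read-out lower numbers stand for an effect already at smaller amounts and higher numbers for an effect only at larger amounts of compound), and so stands at the highest of the three numbers measured. Compound 1 `CC(C)(C)N(NC(=O)c1ccccc1)C(=O)c1ccccc1Cl` gives 75.9 nM, and compound 2 `CC(C)(C)N(NC(=O)c1ccccc1F)C(=O)c1ccccc1Cl` gives 51.3 nM. Compound 4 `CC(C)(C)N(NC(=O)c1ccccc1Br)C(=O)c1ccccc1Cl` is not yet measured; it differs from compound 3 by bromo in place of chloro on an aromatic carbon, the change sitting ortho to a large group.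

Within the data shown here, the steps that bear on this are those that put a halogen at the same aromatic carbon: a 4.4-fold higher number from compound 1 to compound 3 (0.64 log units; beyond the scatter) and a 6.5-fold higher number from compound 2 to compound 3 (0.81 log units; beyond the scatter). Both go the same way, while a 1.5-fold lower number from compound 1 to compound 2 (0.17 log units; within the scatter) shows that fluoro and hydrogen are not separated. Larger halogen, higher number, is the only pattern these three compounds offer, and none of them goes against it. Bromo in place of chloro is therefore expected to give a small further rise in this assay, or at most one near the scatter; an expected step of a 1.7-fold higher number from compound 3 to compound 4 (0.22 log units; within the scatter). Compound 4 is thus estimated at 550 nM, within 200 nM to 1500 nM.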

Compound 4, half-maximal effective concentration: 316 nM
The estimate for compound 4 lay 1.7-fold (0.24 log units) above the measured number; measured number inside the range.
By their numbers in this assay, from the lowest: compounds 2 and 1 (each within the scatter of the next); then compounds 4 and 3 (each within the scatter of the next).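

In this assay, chloro and bromo on this aromatic carbon are not separated, with a 1.0-fold lower number from compound 3 to compound 4 (0.02 log units; within the scatter). Both halogens instead sit apart from fluoro and hydrogen, as shown by a 6.2-fold higher number from compound 2 to compound 4 (0.79 log units; beyond the scatter) and by a 4.2-fold higher number from compound 1 to compound 4 (0.62 log units; beyond the scatter), so the series now reads as two groups and the earlier rise with halogen size does not carry on from chloro to bromo. Nothing measured here speaks to the origin of this grouping.

Open, from the compounds shown here alone, is whether iodo would stay with chloro and bromo or fall with fluoro and hydrogen, and how a non-halogen group such as methyl, methoxy or an amine would read on this same carbon. Also open, going by these compounds, is whether the two groups persist when the shared core is changed elsewhere.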